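A few compounds are considered here, and "the series" means these few. Any claim that something is new, unique, unknown or untested is made for them only; others in the source may bear on it.

The series shares one core, seen in compound 1 `CS(=O)(=O)OC(c1ccccc1)c1cc2ccccc2o1`, in which a single saturated chain carbon bound to two aromatic carbons carries the group that changes. In a functional assay on A549 cells (Homo sapiens) for inhibition, read by MTT assay, with a stated time of 48 h (on this read-out lower numbers stand for stronger inhibition and higher numbers for weaker inhibition), compound 1 gives > 40000 nM, which is a limit of the assay rather than a number. Compound 2 `c1ccc(C(c2cc3ccccc3o2)n2ccnc2)cc1` carries a 1H-imidazol-1-yl in place of the (methylsulfonyl)oxy, and in this assay compound 2 gives > 40000 nM, again a limit. Compound 3 `Cc1nccn1C(c1ccccc1)c1cc2ccccc2o1` carries a 2-methyl-1H-imidazol-1-yl there instead, and in this assay compound 3 gives > 40000 nM, also a limit. The three steps, a step that the two limits leave unreadable from compound 1 to compound 2, a step that the two limits leave unreadable from compound 1 to compound 3 and a step that the two limits leave unreadable from compound 2 to compound 3, cannot be sized because all three values sit at the limit of > 40000 nM in this assay, at which 3 of the 3 values shown sit. Compound 3 therefore stands at that limit together with the others, with no ordering among them.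

Compound 4 `CCc1nccn1C(c1ccccc1)c1cc2ccccc2o1` differs from compound 3 by methyl in place of hydrogen on a saturated chain carbon bound to an aromatic carbon. Within the data shown here, no measured step bears on this change in a readable way, and the only step on the same group, a step that the two limits leave unreadable from compound 2 to compound 3, is itself unreadable. What the data show is that none of the three compounds reached a measurable value in this assay. Compound 4 is therefore expected to sit at the limit as well, the expected step that the limit leaves unreadable from compound 3 to compound 4 carrying no readable direction. The estimate for compound 4 is 60000 nM, between 20000 nM and 300000 nM.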

Compound 4, half-maximal inhibitory concentration: > 40000 nM
Compound 4 was reported as a limit (the forecaster's own chance of this, stated with the estimate: 85%); the middle value does not contradict the limit.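

In this assay compound 4 gives > 40000 nM, again a limit, so no new step can be read among compound 1, compound 2, compound 3 and compound 4: the limit of > 40000 nM in this assay, at which 4 of the 4 values shown sit.

The compounds shown leave open whether any group on the saturated chain carbon of the shared core gives a measurable value in this read-out, and how these four compounds rank.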